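The source may report more compounds than this note shows. Statements on the series, on what has been measured and on what is new or still open speak of the compounds shown alone.

Values in a physicochemical assay for lipophilicity, measured as chromatographic lipophilicity, at pH 7.4 (a lower number here means a more polar compound, a higher number a more lipophilic compound), for the measured compounds
Compound 1 `COc1cc(-c2nnc3n2CCCC3c2ccc(Cl)c(Cl)c2)ccc1-c1cnc(C)o1` gives 3.2
Compound 2 `COc1cc(-c2nnc3n2CCCC3(c2ccc(F)c(F)c2)C(C)(C)O)ccc1-c1cnc(C)o1` gives 2.9

Compound 2 at 2.9 stands within the usual scatter of compound 1 and the two cannot be told apart. Compound 3 `COc1cc(-c2nnc3n2CCCC3(Oc2ccc(F)c(F)c2)C(C)(C)O)ccc1-c1cnc(C)o1` has not yet been measured in this assay and carries 3,4-difluorophenoxy in place of 3,4-difluorophenyl on a saturated ring carbon of a six-membered non-aromatic ring with 1 nitrogen, two ring bonds from the ring nitrogen. Among the compounds with values here, no pair of measured compounds shows this change on its own, so the data do not fix its size. The expectation rests on compound 2 at 2.9 and on the structural change alone. The estimated step is a number 0.10 log units higher from compound 2 to compound 3 (within the scatter) and is expected to stay inside the usual scatter. For compound 3 the expected value is 3 with 2.6 to 3.4 as the estimated range.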

Compound 3, distribution coefficient: 2.8
The estimate for compound 3 lay 0.20 log units above the measured number, within the range that was stated.
By their numbers in this assay, from the lowest: compounds 3, 2 and 1 (each within the scatter of the next, the first and the last beyond it).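

In this assay, within the data shown here, replacing 3,4-difluorophenyl with 3,4-difluorophenoxy on a saturated ring carbon, two ring bonds from the ring nitrogen, gives the first direct reading of this change: the step is a number 0.10 log units lower from compound 2 to compound 3 (within the scatter) and the two compounds cannot be told apart. At this position, then, the oxygen atom that enters with the phenoxy group leaves no measurable difference in this pair. The data offer no measurement that explains this result.

On these data alone, this is a single pair, so it remains open whether the same change would read alike on a compound that differs elsewhere. Also open, as far as these compounds go, is how an amine or a longer chain at this ring carbon, in place of the 3,4-difluorophenoxy group, would read in this assay on the same core.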